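The compounds below may be only part of what the source reports. "The series", "measured", "known", "first", "only" and "open" are said of these compounds alone.

- Compound 1 `CCOc1cc([C@](O)(CCN(C)C)[C@@H](c2cc3cc(Br)ccc3nc2OC)c2cccc(OC)c2F)cc(OC)n1`: 19 mL/min/kg
- Compound 2 `CCOc1cc([C@](O)(CCN(C)C)[C@H](c2cccc(C)c2)c2cc3cc(Br)ccc3nc2OC)cc(OC)n1`: 12 mL/min/kg
- Compound 3 `COc1cc([C@](O)(CCN(C)C)[C@@H](c2cc3cc(Br)ccc3nc2OC)c2cccc(OC)c2F)cc(OC(C)C)n1`: not yet measured

These numbers come from an ADME assay on the whole organism (Mus musculus, strain CD-1) for pharmacokinetics; on this read-out lower numbers stand for slow clearance and higher numbers for fast clearance. Within the data shown here, compound 1 has the higher of the two numbers, but the only measured step, a 1.6-fold lower number from compound 1 to compound 2 (0.20 log units; within the scatter), does not separate it from compound 2.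

Compound 3 differs from compound 1 at a single place, where ethoxy becomes isopropoxy: methyl in place of hydrogen on a saturated chain carbon bound to an oxygen on an aromatic ring and a saturated chain carbon. In words, a methyl stands in place of a hydrogen on a saturated chain carbon bound to an oxygen on an aromatic ring and a saturated chain carbon.

Among the measured compounds shown here, no measured step touches this place, so the evidence is indirect. For the measured compounds named here, the one step available swaps a different group, and that change from compound 1 stayed within the scatter at a 1.6-fold lower number from compound 1 to compound 2 (0.20 log units; within the scatter). With so little to go on, no shift beyond the scatter is expected in this assay, and no direction can be favoured with confidence. The estimated change is a 1.1-fold lower number from compound 1 to compound 3 (0.02 log units; within the scatter). For compound 3 the expected value is 18 mL/min/kg, with an estimated range from 9 mL/min/kg to 36 mL/min/kg.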

Compound 3, clearance: 8.9 mL/min/kg
The estimate for compound 3 lay 2.0-fold (0.31 log units) above the measured number; measured number below the stated range.
By their numbers in this assay, from the lowest: compounds 3, 2 and 1 (each within the scatter of the next, the first and the last beyond it).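

In this assay, the swap of ethoxy for isopropoxy, which adds one methyl in place of a hydrogen, gives a 2.1-fold lower number from compound 1 to compound 3 (0.33 log units; beyond the scatter) and so shows that this position can respond to a very small change, a single extra carbon. The only other step shown, a 1.6-fold lower number from compound 1 to compound 2 (0.20 log units; within the scatter), changes a different part of the molecule and stays within the scatter, so this modest step is the only one of the two that clearly moves the number. Nothing measured here explains why one methyl at this place has this effect.

From the compounds shown here alone, it remains open whether a longer chain such as propoxy, or a more branched group such as tert-butoxy, would lower the number further, keep it where it stands or raise it again, since one step cannot show a trend. Going by these compounds, it is also open whether the same ethoxy to isopropoxy swap would have a similar effect on compound 2, which carries 3-methylphenyl in place of 2-fluoro-3-methoxyphenyl, or whether this step holds only with the rest of compound 1 around it.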